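One Chloropyridine for Another on a Shared Core

The compounds below may be only part of what the source reports. "The series", "measured", "known", "first", "only" and "open" are said of these compounds alone.

Of the compounds shown here, three built on one shared core have been tested in an ADME assay on HepG2 cells (Homo sapiens) for inhibition, with a stated time of 72 h; on this read-out lower numbers stand for an effect already at smaller amounts and higher numbers for an effect only at larger amounts of compound. Compound 1 `CN(C)CCC(=O)Nc1cccc(-c2nc3ccccc3s2)c1` gives 21000 nM. Compound 2 `CC(Cl)C(=O)Nc1cccc(-c2nc3ccccc3s2)c1` reaches only the limit of the assay, > 25000 nM, which is a boundary rather than a number. Compound 3 `O=C(Nc1cccc(-c2nc3ccccc3s2)c1)c1ccc(Cl)nc1Cl` likewise stops at the limit, > 25000 nM, so where it stands is known only as that boundary. Two of the three values sit there (the limit of > 25000 nM in this assay, at which 2 of the 3 values shown sit).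

The next compound, compound 4 `O=C(Nc1cccc(-c2nc3ccccc3s2)c1)c1ccnc(Cl)c1`, differs from compound 3 in one place: 2-chloropyridin-4-yl in place of 2,6-dichloropyridin-3-yl on a carbonyl carbon. Of the measured steps, those that exchange the group on the carbonyl carbon bear on this change. Both an at least 1.1-fold higher number from compound 1 to compound 3 (0.07 log units; that floor lies within the scatter) and an at least 1.1-fold higher number from compound 1 to compound 2 (0.07 log units; that floor lies within the scatter) reach only a floor that lies within the scatter, and a step that the two limits leave unreadable from compound 2 to compound 3. None of them shows that swapping this group moves the read-out beyond the scatter, and the two limits leave the comparison between compound 2 and compound 3 open. The step expected in this assay is therefore a number no higher from compound 3 to compound 4 (the limit leaves the size open), none beyond the scatter. Compound 4 is estimated at 25000 nM, within 12000 nM to 60000 nM, with a real chance that it too returns only a limit.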

Compound 4, half-maximal effective concentration: > 25000 nM
Compound 4: a limit, no number; the forecaster's own chance of this, stated with the estimate: 60%; the middle value sits exactly at the limit.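

In this assay compound 4 returns only a limit, so a second chloropyridine on the carbonyl carbon, now 2-chloropyridin-4-yl with one chlorine in place of 2,6-dichloropyridin-3-yl with two, also yields no number. Among the compounds shown here, the steps that link compound 4 to compound 2 and compound 3 cannot be read, and the one step that can be read, an at least 1.1-fold higher number from compound 1 to compound 4 (0.07 log units; that floor lies within the scatter), shows no change beyond the scatter. Compound 1, with its 2-(dimethylamino)ethyl group, is still the only one of the four compounds with a measured number, and the limit now holds most of the set: the limit of > 25000 nM in this assay, at which 3 of the 4 values shown sit.

On these data alone, whether the two chloropyridines, or either of them and the 1-chloroethyl group, truly differ in this read-out stays open, since a limit does not tell how far apart such compounds lie. Also open, as far as these compounds go, is whether a different group on the carbonyl carbon, such as a carboxylic acid or a piperidine ring, would give a number clearly apart from that of compound 1.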